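This account rests on a few compounds, and the source may have more. Where it says the series, first, only, none or still open, it means among the compounds named here.

Of the compounds shown here, three sharing one core have been measured in a functional assay on HeLa cells (Homo sapiens) for inhibition, read by MTT assay, with a stated time of 72 h; a higher number here means a weaker inhibitor, a lower number a stronger inhibitor. Compound 1 `CC/C=C/C(=O)Nc1cccc(Oc2nc(Nc3cccc(OC)c3)nc3ccsc23)c1` gives 29400 nM, the highest of the three numbers. Compound 2 `COc1cccc(Nc2nc(Oc3cccc(NC(=O)/C=C/C(C)C)c3)c3sccc3n2)c1` gives 27000 nM, and compound 3 `CCC/C=C/C(=O)Nc1cccc(Oc2nc(Nc3cccc(OC)c3)nc3ccsc23)c1` gives 7730 nM. The measured steps are a 1.1-fold lower number from compound 1 to compound 2 (0.04 log units; within the scatter), a 3.8-fold lower number from compound 1 to compound 3 (0.58 log units; beyond the scatter) and a 3.5-fold lower number from compound 2 to compound 3 (0.54 log units; beyond the scatter); every one of these changes sits on the amide chain.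

Compound 4 `CC/C=C/C(=O)Nc1cccc(Oc2nc(Nc3cccc(C#N)c3)nc3ccsc23)c1` differs from compound 1 in a different place: cyano in place of methoxy on an aromatic carbon. None of the three measured steps touches the (3-methoxyphenyl)amino part, so none of them bears on this change, and the measured compounds give no direction for it. In this assay the expected step is therefore a 1.2-fold lower number from compound 1 to compound 4 (0.07 log units; within the scatter), a number expected to stay close to the starting point, with a wide range to reflect the absence of any comparable step. The estimate for compound 4 in this assay is 25000 nM, expected to fall between 6000 nM and 100000 nM.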

Compound 4, half-maximal inhibitory concentration: 69400 nM
Estimate against measurement, compound 4: 2.8-fold (0.44 log units) below; measured number inside the range.
By their numbers in this assay, from the lowest: compound 3; then compounds 2 and 1 (each within the scatter of the next); then compound 4.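

Among the compounds shown here, the (3-methoxyphenyl)amino part, untouched by the earlier steps, turns out to matter in this assay: cyano in place of methoxy on this aromatic carbon gives a 2.4-fold higher number from compound 1 to compound 4 (0.37 log units; beyond the scatter) and so moves the number beyond the scatter. For the compounds shown here, this is the first change outside the amide chain, and it runs upward, whereas the chain change that goes beyond the scatter from compound 1 runs downward, so the number responds at both sites. Nothing shown accounts for the rise.

On these data alone, with one pair, the loss of methoxy cannot be told apart from the gain of cyano, and how a hydrogen, a chlorine or an amine at this carbon would read remains open. As far as these compounds go, it also remains open whether the same exchange would shift compound 3, with its longer chain, in the same way.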